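Methyl shift on the thiazolyl ring of compound 3

The source may hold more compounds than are shown below. What is called first, only, known or untested is meant among the compounds shown, and "the series" means these compounds.

Compound 1 `c1coc(-c2ccccc2OCC2=NCCN2)c1`: 1.26 nM in a functional assay for activation of Alpha-1A adrenergic receptor (Homo sapiens), read by calcium flux; on this read-out higher numbers stand for an effect only at larger amounts of compound and lower numbers for an effect already at smaller amounts
Compound 2 `c1ccc(-c2cc[nH]n2)c(OCC2=NCCN2)c1`: 5.01 nM
Compound 3 `Cc1cc(-c2ccccc2OCC2=NCCN2)sn1`: 158 nM

Compound 3 carries the highest number of the three: a 32-fold higher number from compound 2 to compound 3 (1.50 log units; beyond the scatter) and a 130-fold higher number from compound 1 to compound 3 (2.10 log units; beyond the scatter), both beyond the scatter. Compound 4 `Cc1cnsc1-c1ccccc1OCC1=NCCN1` is its isomer, with 4-methyl-1,2-thiazol-5-yl in place of 3-methyl-1,2-thiazol-5-yl on an aromatic carbon. Going by the values given here, none of the measured steps bears directly on this change; the step of a 4.0-fold higher number from compound 1 to compound 2 (0.60 log units; beyond the scatter) and the two steps above each exchange one ring for a different one, whereas here only the methyl moves within the same ring. Among the compounds with values here, with no direct precedent, the estimated step is a 1.0-fold higher number from compound 3 to compound 4 (0.01 log units; within the scatter), expected to stay within the scatter. Compound 4 is thus estimated at 160 nM, with a range from 40 nM to 650 nM.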

Compound 4, half-maximal effective concentration: 12.6 nM
For compound 4 the middle estimate is 13-fold (1.10 log units) above the measured one, outside the stated range (below it).
By their numbers in this assay, from the lowest: compound 1; then compound 2; then compound 4; then compound 3.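

In this assay the place of the methyl on the ring counts on its own: a 13-fold lower number from compound 3 to compound 4 (1.10 log units; beyond the scatter), with the same atoms joined differently, whereas every earlier step exchanged one ring for another. The 4-methyl-1,2-thiazol-5-yl group still does not reach the other two rings, giving a 2.5-fold higher number from compound 2 to compound 4 (0.40 log units; beyond the scatter) and a 10-fold higher number from compound 1 to compound 4 (1.00 log units; beyond the scatter). No measurement at hand accounts for the effect of moving the methyl.

On these data alone, it remains open whether an ethyl or an amino group in place of the methyl of 4-methyl-1,2-thiazol-5-yl would keep the lower number. Also open, as far as these compounds go, is where the 1,2-thiazol-5-yl ring without any methyl would fall relative to compound 3 and compound 4.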